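From an alkyne chain to a methoxyethoxy ether

A few compounds are considered here, and "the series" means these few. Any claim that something is new, unique, unknown or untested is made for them only; others in the source may bear on it.

Within the data shown here, compound 1 `CC#CCCOc1cccc2ccc(N)nc12` is one of three compounds measured in an assay on cells with melanin-concentrating hormone receptor 1 (Homo sapiens) as the target, read by radioligand binding; a higher number here means a weaker inhibitor, a lower number a stronger inhibitor. In this assay compound 1 returns only a limit, > 2000 nM. Compound 3 `Nc1ccc2cccc(OC3CCCC3)c2n1` likewise returns only a limit in this assay, > 2000 nM. The step that the two limits leave unreadable from compound 1 to compound 3 therefore cannot be read, since both of its ends are at the limit of > 2000 nM in this assay, at which 2 of the 3 values shown sit. Among the measured compounds shown here, compound 2 `Nc1ccc2cccc(OCC3CC4CCC3C4)c2n1` is the only one with a number, giving 137 nM in this assay.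

Compound 4 `COCCOCCOc1cccc2ccc(N)nc12` has not yet been measured. It differs from compound 1 by 2-methoxyethoxy in place of prop-1-yn-1-yl on a saturated chain carbon, two bonds along the chain from an oxygen on an aromatic ring. For the measured compounds named here, no measured step covers this change: the only measured step is unreadable, and compound 2 differs from compound 1 in a way for which no step has been measured. Compound 1 stands at a limit, so neither direction nor size can be read from the numbers. Compound 4 is expected to give about 3000 nM in this assay, within a range from 800 nM to 15000 nM. This estimate means a step that the limit leaves unreadable from compound 1 to compound 4, which is expected to stay within the scatter, and a limit is the most likely outcome.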

Compound 4, half-maximal inhibitory concentration: > 2000 nM
Compound 4 was reported as a limit; the forecaster's own chance of this, stated with the estimate: 65%; the middle value lies beyond the limit too.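

No new step can be read from compound 1 to compound 4, since both return only a limit in this assay: the limit of > 2000 nM in this assay, at which 3 of the 4 values shown sit.

The compounds shown leave open how compound 1, compound 3 and compound 4 would stand against one another beyond that limit.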